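Thioether chain replacing the phenyl on the ring nitrogen

The source may hold more compounds than are shown below. What is called first, only, known or untested is meant among the compounds shown, and "the series" means these compounds.

Compound 3 `CN1CCN(c2nc3ccccc3n2-c2ccccc2)CC1` gives the highest number of the three measured, 760 nM in a functional assay on ileum for inhibition of histamine H1 receptor (Cavia porcellus); a higher number here means a weaker inhibitor, a lower number a stronger inhibitor. Compound 1 `CCOCCn1c(N2CCN(C)CC2)nc2ccccc21` gives 10 nM in this assay, and compound 2 `CCSCCn1c(N2CCN(C)CC2)nc2ccccc21` gives 19 nM. Compound 4 `CCCSCn1c(N2CCN(C)CC2)nc2ccccc21` carries (propylsulfanyl)methyl in place of phenyl on an aromatic nitrogen. Going by the values given here, the steps that bear on it are a 76-fold higher number from compound 1 to compound 3 (1.88 log units; beyond the scatter) and a 40-fold higher number from compound 2 to compound 3 (1.60 log units; beyond the scatter), both large; the step of a 1.9-fold higher number from compound 1 to compound 2 (0.28 log units; within the scatter) shows that swapping ethoxy for ethylsulfanyl within such a chain changes little. The entering chain resembles that of compound 2, so a large drop in the number is expected, roughly reversing the second of those steps, though the chain differs in shape and some loss is allowed for. Compound 4 is expected to show a 19-fold lower number from compound 3 to compound 4 (1.28 log units; beyond the scatter). The estimate for compound 4 is 40 nM, with a range from 10 nM to 160 nM.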

Compound 4, half-maximal inhibitory concentration: 68 nM
Compound 4: the middle estimate sits 1.7-fold (0.23 log units) below what was measured; the measured number falls inside the stated range.
By their numbers in this assay, from the lowest: compounds 1 and 2 (each within the scatter of the next); then compound 4; then compound 3.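

In this assay, the (propylsulfanyl)methyl chain keeps much of the gain over phenyl (an 11-fold lower number from compound 3 to compound 4 (1.05 log units; beyond the scatter)). The placement of sulfur along the chain is not indifferent, however: moving from the 2-(ethylsulfanyl)ethyl chain gives a modest loss (a 3.6-fold higher number from compound 2 to compound 4 (0.55 log units; beyond the scatter)), and the step from the 2-ethoxyethyl chain is similar in kind (a 6.8-fold higher number from compound 1 to compound 4 (0.83 log units; beyond the scatter)). No supporting evidence accounts for this difference.

Still open, going by these compounds, is whether an ether chain with its oxygen in the same place as the sulfur of compound 4 behaves alike. Also open, on these data alone, is how a longer chain or a terminal amine on this nitrogen would fare.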